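A Bulkier Hydroxylated Ring Replaces the Aminoethyl Chain

The compounds below may be only part of what the source reports. "The series", "measured", "known", "first", "only" and "open" are said of these compounds alone.

Compound 1 `NCCOc1ccc([C@H]2CC[C@]3(CC2)OOC2(O3)C3CC4CC(C3)CC2C4)cc1` gives 1370 ng.h/mL in an ADME assay on the whole organism (strain FVB) for pharmacokinetics, with Mus musculus as the target, read by LC-MS, at a dose of 30 mg/kg by the oral route (a higher number here means more compound in the circulation at the dose given, a lower number less compound in the circulation), the lowest of the three numbers shown. Compound 2 `CC(C)(O)CN1CCC(Oc2ccc([C@H]3CC[C@]4(CC3)OOC3(O4)C4CC5CC(C4)CC3C5)cc2)CC1` gives 14200 ng.h/mL and compound 3 `CC(C)(CN)Oc1ccc([C@H]2CC[C@]3(CC2)OOC2(O3)C3CC4CC(C3)CC2C4)cc1` gives 4840 ng.h/mL in this assay. Compound 4 `CC1(C)CC(O)(COc2ccc([C@H]3CC[C@]4(CC3)OOC3(O4)C4CC5CC(C4)CC3C5)cc2)CC(C)(C)N1` differs from compound 1 by 4-hydroxy-2,2,6,6-tetramethylpiperidin-4-yl in place of aminomethyl on a saturated chain carbon bound to an oxygen on an aromatic ring. Both earlier changes on the same oxygen raised exposure: a 10-fold higher number from compound 1 to compound 2 (1.02 log units; beyond the scatter) and a 3.5-fold higher number from compound 1 to compound 3 (0.55 log units; beyond the scatter). Among the compounds with values here, each swapped the small chain for a larger, branched group, as the change to compound 4 does, and the group entering compound 4 brings a ring, as the group entering compound 2 does, though no step between compound 2 and compound 4 has been measured. For compound 4 a rise beyond the scatter is therefore expected, a 3.6-fold higher number from compound 1 to compound 4 (0.56 log units; beyond the scatter). Compound 4 is estimated at 5000 ng.h/mL, between 1600 ng.h/mL and 16000 ng.h/mL.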

Compound 4, area under the concentration-time curve: 17300 ng.h/mL
Estimate against measurement, compound 4: 3.5-fold (0.54 log units) below, and the stated range ends below it.
By their numbers in this assay, from the lowest: compound 1; then compound 3; then compounds 2 and 4 (each within the scatter of the next).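

The 4-hydroxy-2,2,6,6-tetramethylpiperidin-4-yl group, in place of aminomethyl on this saturated chain carbon, raises the number in this assay (a 13-fold higher number from compound 1 to compound 4 (1.10 log units; beyond the scatter)) and also clears the branched open chain (a 3.6-fold higher number from compound 3 to compound 4 (0.55 log units; beyond the scatter)). The two groups that hold a six-membered non-aromatic ring cannot be told apart (a 1.2-fold higher number from compound 2 to compound 4 (0.09 log units; within the scatter)). Nothing available explains these numbers.

On these data alone, whether the gain rests on the ring hydroxyl or on the four methyl groups stays open. So does the outcome for an unsubstituted piperidine or a carboxylic acid at this place.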